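The source may report more compounds than this note shows. Statements on the series, on what has been measured and on what is new or still open speak of the compounds shown alone.

Of the compounds shown here, two carry numbers so far. In a functional assay on the whole organism with Mus musculus as the target (a lower number here means a stronger inhibitor, a higher number a weaker inhibitor), compound 1 `COc1nc(CBr)c([N+](=O)[O-])c(OC)n1` gives 8000000 nM. Compound 2 `CNc1nc(OC)nc(C(Br)Br)c1[N+](=O)[O-]` gives 2300000 nM in this assay. Compound 2 thus stands lowest of the two numbers, and its gap to compound 1 lies beyond the scatter, so compound 2 is the stronger inhibitor of the pair. Compound 3 `COc1nc(C(Br)Br)c([N+](=O)[O-])c(N2CCCCC2)n1` has not yet been measured. It differs from compound 2 in one place (piperidin-1-yl in place of methylamino on an aromatic carbon). Going by the values given here, no pair of measured compounds separated by a single change exists here, so nothing shows how such an exchange on this aromatic carbon moves the readout. A step of a 1.2-fold lower number from compound 2 to compound 3 (0.06 log units; within the scatter) is expected, which is no larger than the usual scatter, in no firm direction. Compound 3 is therefore estimated at 2000000 nM in this assay, with a range from 700000 nM to 6000000 nM.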

Compound 3, half-maximal inhibitory concentration: 540000 nM
Estimate against measurement, compound 3: 3.7-fold (0.57 log units) above; the measured number lies below the stated range.
By their numbers in this assay, from the lowest: compound 3; then compound 2; then compound 1.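

In this assay, going by these compounds alone, piperidin-1-yl in place of methylamino on the aromatic carbon ortho to a nitro group gives a 4.3-fold lower number from compound 2 to compound 3 (0.63 log units; beyond the scatter) and is the first single-change step. This carbon therefore responds to the group it carries, and a six-membered non-aromatic ring with 0 hydrogen-bond donors is accepted here with no loss of inhibition. Nothing on hand accounts for the size or direction of this step.

Still open, as far as these compounds go, is whether the ring itself, the absence of the amine hydrogen or the larger group goes with the lower number; dimethylamino, pyrrolidin-1-yl and morpholin-4-yl on this carbon would separate these readings. The contribution of the dibromomethyl group also remains open, as no compounds shown differ only at that group.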